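The source may report more compounds than this note shows. Statements on the series, on what has been measured and on what is new or still open speak of the compounds shown alone.

Compound 1 `Cc1ccc2nc(-c3ccccc3N(C)C)[nH]c(=O)c2c1` gives 14000 nM in a functional assay on HeLa cells (Homo sapiens) for cytotoxicity, read by MTT assay, with a stated time of 2 days; on this read-out higher numbers stand for weaker inhibition and lower numbers for stronger inhibition. Compound 2 `Cc1ccc2c(=O)[nH]c(-c3ccccc3F)nc2c1` gives 830 nM. Compound 3 `Cc1ccc2nc(-c3ccccc3F)[nH]c(=O)c2c1` gives > 50000 nM, which is a limit of the assay.

For compound 3 only a limit is recorded, (the limit of > 50000 nM in this assay, at which 1 of the 3 values shown sits). Compound 2 and compound 3 have the same atoms joined differently; the difference between the two cores is not broken down here. Compound 2 holds the lowest of the two numbers, with compound 1 next. The change dimethylamino in place of fluoro on an aromatic carbon gave an at least 3.5-fold lower number from compound 3 to compound 1 (0.55 log units; beyond the scatter). Compound 4 `Cc1ccc2c(=O)[nH]c(-c3ccccc3N(C)C)nc2c1` has not been measured; it arises from compound 2 by the same kind of change, (dimethylamino in place of fluoro on an aromatic carbon), again ortho to a large group. The expectation for compound 4 rests on that measured step, an at least 3.5-fold lower number from compound 3 to compound 1 (0.55 log units; beyond the scatter), and on compound 2 giving 830 nM. Compound 4 is therefore expected to give about 350 nM, between 90 nM and 2000 nM, an expected step of a 2.4-fold lower number from compound 2 to compound 4 (0.38 log units; beyond the scatter).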

Compound 4, half-maximal inhibitory concentration: 43800 nM
For compound 4 the middle estimate is 130-fold (2.10 log units) below the measured one; the whole stated range lies below it.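

In this assay, dimethylamino in place of fluoro on an aromatic carbon gave a 53-fold higher number from compound 2 to compound 4 (1.72 log units; beyond the scatter), while the same change on the other core ran the opposite way: the same change on two cores in this assay, an at least 3.5-fold lower number (0.55 log units; beyond the scatter) from compound 3 to compound 1 and a 53-fold higher number (1.72 log units; beyond the scatter) from compound 2 to compound 4, at least 180-fold (2.27 log units) apart, beyond the scatter of two such steps

Compound 3 is recorded only as a limit of the assay, > 50000 nM, so the earlier step is known only as a bound. The two steps show that the result of this change did not carry from one core to the other, even in direction, but with one pair on each core they do not show why.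

The compounds shown leave open whether a primary amine or a methoxy group in the same place would follow the pattern of either core.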